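The source may report more compounds than this note shows. Statements on the series, on what has been measured and on what is new or still open speak of the compounds shown alone.

Measured so far:
- compound 1 `COc1ccc(-c2cncnc2-c2cc(OC)c(OC)c(OC)c2)cc1`: 2850 nM
- compound 2 `COc1ccc(-c2cncnc2-c2cc(OC)c(OC)c(OC)c2)cc1F`: 3340 nM

In a functional assay on SiHa cells (Homo sapiens) for antiproliferative activity, read by CCK-8 assay, with a stated time of 72 h (a higher number here means a weaker inhibitor, a lower number a stronger inhibitor), compound 1 gives the lower of the two numbers, though compound 2 sits within the scatter of it, so the two cannot be told apart. Compound 3 `COc1cc(-c2ncncc2-c2ccc(C(N)=O)cc2)cc(OC)c1OC` differs from compound 1 by carbamoyl in place of methoxy on an aromatic carbon. For the measured compounds named here, the only measured step, a 1.2-fold higher number from compound 1 to compound 2 (0.07 log units; within the scatter), exchanges a hydrogen for fluoro and says nothing about replacing methoxy with carbamoyl. Going by the values given here, with no step to guide the expectation, compound 3 is estimated at 5000 nM, within 1500 nM to 20000 nM, which means an expected step of a 1.8-fold higher number from compound 1 to compound 3 (0.24 log units; within the scatter).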

Compound 3, half-maximal inhibitory concentration: > 100000 nM
Compound 3: only a limit was reported (the forecaster's own chance of this, stated with the estimate: 10%); middle value at least 20-fold (1.30 log units) away from the limit.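

The earlier fluoro step lay within the scatter, but this position proves far more sensitive: carbamoyl in place of methoxy brings an at least 35-fold higher number from compound 1 to compound 3 (1.54 log units; beyond the scatter), and 4-carbamoylphenyl in place of 3-fluoro-4-methoxyphenyl brings an at least 29-fold higher number from compound 2 to compound 3 (1.47 log units; beyond the scatter). In this assay compound 3 gives > 100000 nM, which is a limit of the assay and not a number. The methoxy on this ring, para to a large group, therefore cannot be swapped for just any group without losing activity. As far as these compounds go, whether a nitrile, a hydroxyl or an acetyl group would keep the activity here stays open.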